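Trading a trifluoromethyl for fluoro on the styryl ring

The source may report more compounds than this note shows. Statements on the series, on what has been measured and on what is new or still open speak of the compounds shown alone.

Measured so far:
compound 1, `COC(=O)/C=C/c1cccc(N(Cc2ccc(/C=C/c3cccc(C(F)(F)F)c3)cc2)C(=O)C(C)C)c1`: 267 nM
compound 2, `COC(=O)/C=C/c1cccc(N(Cc2ccc(/C=C/c3cccc(C(F)(F)F)c3)cc2)C(=O)NC(C)C)c1`: 932 nM
compound 3, `COC(=O)/C=C/c1cccc(N(C(=O)C2CCCCC2)c2ccc3ccccc3c2)c1`: 680 nM

All three were tested in an assay on isolated protein with Bile acid receptor (Homo sapiens) as the target; on this read-out higher numbers stand for an effect only at larger amounts of compound and lower numbers for an effect already at smaller amounts. Compound 2 gives 932 nM, and compound 3 gives 680 nM, a value that lies within the usual scatter of that of compound 2. Among the measured compounds shown here, compound 1 sits further away: the one change that separates it from compound 2, isopropylamino in place of isopropyl on a carbonyl carbon, gives a 3.5-fold higher number from compound 1 to compound 2 (0.54 log units; beyond the scatter), a step beyond the scatter.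

Compound 4, `COC(=O)/C=C/c1cccc(N(Cc2ccc(/C=C/c3cccc(F)c3)cc2)C(=O)NC(C)C)c1`, keeps the isopropylamino side of compound 2 and alters the far end instead: fluoro in place of trifluoromethyl on an aromatic carbon.

For the measured compounds named here, no measured pair shows this particular change; the only measured step concerns the carbonyl substituent, not the substituted phenyl at the end of the ethenyl bridge. There is therefore no basis for expecting a shift in either direction, and the estimate for compound 4 is a step of a 1.2-fold higher number from compound 2 to compound 4 (0.07 log units; within the scatter), which lies within the scatter. The expected value for compound 4 in this assay is 1100 nM, with a range from 400 nM to 3200 nM.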

Compound 4, half-maximal effective concentration: 467 nM
Compound 4: middle estimate off by 2.4-fold (0.37 log units), on the high side, and the stated range covers the measured number.
By their numbers in this assay, from the lowest: compounds 1, 4, 3 and 2 (each within the scatter of the next, the first and the last beyond it).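

In this assay, replacing trifluoromethyl with fluoro on this aromatic carbon shrinks the group from four heavy atoms to one and gives a 2.0-fold lower number from compound 2 to compound 4 (0.30 log units; within the scatter), so the two compounds cannot be told apart on this read-out. Among the compounds shown here, this is the first look at this position, and it shows that the full trifluoromethyl group is not needed to keep the number in this range, at least with the isopropylamino carbonyl in place. The only step beyond the scatter among these compounds remains the one at the carbonyl, a 3.5-fold higher number from compound 1 to compound 2 (0.54 log units; beyond the scatter), and no separate measurement bears on what lies behind the new result.

From the compounds shown here alone, it remains open whether the same swap would read alike with the isopropyl carbonyl of compound 1. Also open, going by these compounds, is how a chlorine, a methoxy group or a plain hydrogen on this aromatic carbon would read, and whether this position would respond differently with a carboxylic acid in place of the methyl ester.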